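Compound 3 to compound 4: methyl for trifluoromethyl

The source may hold more compounds than are shown below. What is called first, only, known or untested is meant among the compounds shown, and "the series" means these compounds.

Measured in a functional assay on ECa-109 cells for inhibition, with ECa-109 cell line (Homo sapiens) as the target, read by sulforhodamine B assay (on this read-out higher numbers stand for weaker inhibition and lower numbers for stronger inhibition), as follows:
- compound 1 `CCCc1ccc(NC2=CC(=O)c3nc4n(c3C2=O)[C@H]2OC[C@@H](O)[C@H]2OC4)cc1` gives > 4000 nM as a limit
- compound 2 `O=C1C=C(Nc2cccc(F)c2)C(=O)c2c1nc1n2[C@H]2OC[C@@H](O)[C@H]2OC1` gives 7030 nM
- compound 3 `O=C1C=C(Nc2ccc(C(F)(F)F)cc2)C(=O)c2c1nc1n2[C@H]2OC[C@@H](O)[C@H]2OC1` gives 5500 nM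

Among the compounds with values here, compound 3 sits together with compound 2 on the numbers, with a 1.3-fold lower number from compound 2 to compound 3 (0.11 log units; within the scatter) as the only readable step. For compound 1 the value > 4000 nM is a limit only.

Compound 4 `Cc1ccc(NC2=CC(=O)c3nc4n(c3C2=O)[C@H]2OC[C@@H](O)[C@H]2OC4)cc1` carries methyl in place of trifluoromethyl on an aromatic carbon, para to a large group, counted as methyl in place of trifluoromethyl on an aromatic carbon in full.

The nearest measured change is a step that the limit leaves unreadable from compound 1 to compound 3 and gives no size. Within the data shown here, the one readable step, a 1.3-fold lower number from compound 2 to compound 3 (0.11 log units; within the scatter) again, offers no reason to expect a larger move. The step expected in this assay is a 1.1-fold lower number from compound 3 to compound 4 (0.04 log units; within the scatter) and nothing beyond the scatter. For compound 4 the estimate is 5000 nM with an expected range from 2500 nM to 10000 nM on this read-out.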

Compound 4, half-maximal inhibitory concentration: 3480 nM
Estimate against measurement, compound 4: 1.4-fold (0.16 log units) above; low and high end bracket the measured number.
By their numbers in this assay, from the lowest: compounds 4, 3 and 2 (each within the scatter of the next, the first and the last beyond it).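

In this assay, methyl in place of trifluoromethyl, para to a large group, gives a 1.6-fold lower number from compound 3 to compound 4 (0.20 log units; within the scatter), so this exchange of 4 heavy atoms for 1 stays within the scatter. Across the aniline substituents, the first step beyond the scatter is a 2.0-fold lower number from compound 2 to compound 4 (0.31 log units; beyond the scatter), a modest step with 4-methylphenyl in place of 3-fluorophenyl. Compound 1 stands at a limit, so the comparison with propyl gives only a floor, an at least 1.1-fold lower number from compound 1 to compound 4 (0.06 log units; that floor lies within the scatter), with this basis: the limit of > 4000 nM in this assay, at which 1 of the 4 values shown sits.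

Still open, going by these compounds, is how an amine or a carboxylic acid at this position would read in this assay.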